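Pyridin-3-yl to pyridin-4-yl: expected clearance step

A few compounds are considered here, and "the series" means these few. Any claim that something is new, unique, unknown or untested is made for them only; others in the source may bear on it.

In an ADME assay (liver) for metabolic stability, with Liver microsome (Rattus norvegicus) as the target, using microsomes (on this read-out higher numbers stand for fast clearance and lower numbers for slow clearance), compound 1 (`Fc1ccccc1CNc1nnc(-c2c[nH]c3ncccc23)o1`) gives 46 mL.min-1.g-1, compound 2 (`Fc1ccc(CNc2nnc(-c3c[nH]c4ncccc34)o2)cc1`) gives 58 mL.min-1.g-1 and compound 3 (`c1cncc(CNc2nnc(-c3c[nH]c4ncccc34)o2)c1`) gives 30 mL.min-1.g-1. Compound 3 therefore stands within the scatter of both other compounds.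

Compound 4 (`c1cnc2[nH]cc(-c3nnc(NCc4ccncc4)o3)c2c1`) has pyridin-4-yl in place of pyridin-3-yl on a saturated chain carbon bound to a nitrogen on an aromatic ring. Within the data shown here, no measured step covers this exact exchange. The closest parallel is a 1.3-fold higher number from compound 1 to compound 2 (0.10 log units; within the scatter), where 4-fluorophenyl replaces 2-fluorophenyl at the same place. Exchanging either fluorophenyl group for pyridin-3-yl gives a 1.5-fold lower number from compound 1 to compound 3 (0.19 log units; within the scatter) and a 1.9-fold lower number from compound 2 to compound 3 (0.29 log units; within the scatter). All three steps lie within the scatter, so no step beyond the scatter is expected in this assay, and neither direction is favoured. The expected step is no change at the digits printed from compound 3 to compound 4 (within the scatter). The estimate for compound 4 is 30 mL.min-1.g-1, with an expected range of 15 mL.min-1.g-1 to 60 mL.min-1.g-1.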

Compound 4, intrinsic clearance in microsomes: 37 mL.min-1.g-1
For compound 4 the middle estimate is 1.2-fold (0.09 log units) below the measured one; the range from low to high includes it.
By their numbers in this assay, from the lowest: compounds 3, 4, 1 and 2 (each within the scatter of the next).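

In this assay, among these compounds, pyridin-4-yl in place of pyridin-3-yl on a saturated chain carbon bound to a nitrogen on an aromatic ring gives a 1.2-fold higher number from compound 3 to compound 4 (0.09 log units; within the scatter) and so provides the first reading of two pyridine groups with the same atoms joined differently at this place. Set against the fluorophenyl compounds, pyridin-4-yl gives a 1.6-fold lower number from compound 2 to compound 4 (0.20 log units; within the scatter) and a 1.2-fold lower number from compound 1 to compound 4 (0.09 log units; within the scatter) and thus, like pyridin-3-yl, stays within the scatter of both. No supporting measurement bears on these results.

All four compounds carry a six-membered aromatic ring at this place, and none of their steps goes beyond the scatter. On these data alone, whether a piperidine ring, a carboxylic acid or a longer chain here would give a step beyond the scatter remains open.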